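From cyano to nitro on an aromatic carbon

The compounds below may be only part of what the source reports. "The series", "measured", "known", "first", "only" and "open" are said of these compounds alone.

In a functional assay on DU-145 cells (Homo sapiens) for antiproliferative activity, read by propidium iodide staining, with a stated time of 96 h (on this read-out higher numbers stand for weaker inhibition and lower numbers for stronger inhibition), compound 1 (`CC(O)(CSc1ccc(S(F)(F)(F)(F)F)cc1)C(=O)Nc1ccc(C#N)c(C(F)(F)F)c1`) gives 27900 nM and compound 2 (`CC(O)(CS(=O)(=O)c1cccc(S(F)(F)(F)(F)F)c1)C(=O)Nc1ccc(C#N)cc1C(F)(F)F`) gives 22100 nM in the same test, so these two compounds stand level within the scatter. Compound 3 (`CC(O)(CS(=O)(=O)c1cccc(S(F)(F)(F)(F)F)c1)C(=O)Nc1ccc([N+](=O)[O-])cc1C(F)(F)F`) has nitro in place of cyano on an aromatic carbon. Within the data shown here, no pair of measured compounds shows this swap, so no step beyond the scatter is expected in this assay for it. The expected step of a 1.1-fold lower number from compound 2 to compound 3 (0.04 log units; within the scatter) is therefore small. The estimated value for compound 3 is 20000 nM (range 8000 nM to 50000 nM).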

Compound 3, half-maximal inhibitory concentration: 100000 nM
Compound 3: middle estimate off by 5.0-fold (0.70 log units), on the low side; the whole stated range lies below it.
By their numbers in this assay, from the lowest: compounds 2 and 1 (each within the scatter of the next); then compound 3.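

Nitro in place of cyano on this aromatic carbon, para to a large group and meta to a trifluoromethyl group, is not a neutral swap: in this assay it gives a 4.5-fold higher number from compound 2 to compound 3 (0.66 log units; beyond the scatter) and so weakens inhibition modestly, beyond the scatter. Compounds 1 and 2 could not show this, as they differ in more than one place. No measurement at hand accounts for the step. Going by these compounds, an amine or a carboxylic acid at this position remains open, as does whether the same swap would weaken inhibition in compound 1.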